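Moving the methylsulfonyl group in a weak antiproliferative series

The source may hold more compounds than are shown below. What is called first, only, known or untested is meant among the compounds shown, and "the series" means these compounds.

Compound 1 `O=C(Nc1ccc(Cl)c(-c2nnc3c(Cl)cccn23)c1)c1ccccn1`: 79000 nM
Compound 2 `CS(=O)(=O)c1ccc(C(=O)Nc2ccc(Cl)c(-c3nnc4c(Cl)cccn34)c2)cc1`: > 100000 nM
Compound 3 `CS(=O)(=O)c1ccc(C(=O)Nc2ccc(Cl)c(-c3nnc4c(Cl)cccn34)c2)c(Cl)c1`: 44600 nM

In a functional assay on U-251 cells (Homo sapiens) for antiproliferative activity, read by MTT assay, with a stated time of 72 h (a higher number here means a weaker inhibitor, a lower number a stronger inhibitor), compound 1 gives 79000 nM. For compound 2 the assay reports only a limit, > 100000 nM, so compound 2 stands at the edge of the measured range rather than on a number (the limit of > 100000 nM in this assay, at which 1 of the 3 values shown sits). Compound 3 gives 44600 nM. The two measured steps are an at least 1.2-fold higher number from compound 1 to compound 2 (0.10 log units; that floor lies within the scatter) and an at least 2.2-fold lower number from compound 2 to compound 3 (0.35 log units; beyond the scatter).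

Compound 4 `CS(=O)(=O)c1cccc(C(=O)Nc2ccc(Cl)c(-c3nnc4c(Cl)cccn34)c2)c1` differs from compound 2 by 3-(methylsulfonyl)phenyl in place of 4-(methylsulfonyl)phenyl on a carbonyl carbon. Neither measured step moves the methylsulfonyl group around its ring: the first exchanges the whole aryl on the carbonyl carbon, the second adds chloro. So they offer no direct guide, and only show that this series sits at weak potency with small steps. Compound 4 is therefore expected to stay close to compound 2, with a step of an at least 1.1-fold lower number from compound 2 to compound 4 (0.04 log units; that floor lies within the scatter) and an estimated 90000 nM, in the range 35000 nM to 250000 nM, with a real chance that only a limit is reported again.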

Compound 4, half-maximal inhibitory concentration: > 100000 nM
Compound 4: no number, only a limit (the forecaster's own chance of this, stated with the estimate: 45%); at least 1.1-fold (0.04 log units) between middle value and limit.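

this assay now gives both methylsulfonyl isomers the same kind of reading, so 3-(methylsulfonyl)phenyl in place of 4-(methylsulfonyl)phenyl on the carbonyl carbon brings no measurable value into range: the limit of > 100000 nM in this assay, at which 2 of the 4 values shown sit. The step between compound 2 and compound 4 cannot be read. Exchanging pyridin-2-yl for 3-(methylsulfonyl)phenyl gives an at least 1.2-fold higher number from compound 1 to compound 4 (0.10 log units; that floor lies within the scatter), so the data fix only a floor for this change, as they did for 4-(methylsulfonyl)phenyl.

From the compounds shown here alone, how far the true values of compound 2 and compound 4 lie beyond the limit remains open, as does whether the chloro added in going to compound 3 would give a measurable value on the 3-(methylsulfonyl)phenyl ring as well. Also open, going by these compounds, is whether an amine or a carboxylic acid in place of the methylsulfonyl group would give a number at all.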